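The source may report more compounds than this note shows. Statements on the series, on what has been measured and on what is new or still open speak of the compounds shown alone.

Measured so far:

Compound 1 `CCc1ccccc1OC(C)C1=NCCN1` — in an assay on CHO cells for displacement of a labelled ligand from Alpha-2B adrenergic receptor (Homo sapiens) (on this read-out lower numbers stand for stronger inhibition and higher numbers for weaker inhibition), compound 1 gives 282 nM
Compound 2 `CCOc1ccccc1OC(C)C1=NCCN1` — in this assay compound 2 gives 1320 nM
Compound 3 `COc1ccccc1OC(C)C1=NCCN1` — in this assay compound 3 gives 871 nM

Among these three numbers compound 3 stands second highest. Its nearest neighbour is compound 2, and the step of a 1.5-fold lower number from compound 2 to compound 3 (0.18 log units; within the scatter) lies within the scatter, so the two cannot be told apart. Compound 1 is the furthest away, as shown by a 3.1-fold higher number from compound 1 to compound 3 (0.49 log units; beyond the scatter).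

Compound 4 `CC(Oc1ccccc1C=O)C1=NCCN1` is the unmeasured member. It differs from compound 3 by formyl in place of methoxy on an aromatic carbon; in words, a formyl in place of a methoxy on the aromatic carbon ortho to the group of 8 heavy atoms.

Among the measured compounds shown here, no measured step exchanges a methoxy for a formyl, so there is no direct precedent. For the measured compounds named here, the steps that bear on the same aromatic carbon are a 3.1-fold higher number from compound 1 to compound 3 (0.49 log units; beyond the scatter) and a 4.7-fold higher number from compound 1 to compound 2 (0.67 log units; beyond the scatter), both modest and both beyond the scatter, showing that this position can shift the number but not by a large amount. The step of a 1.5-fold lower number from compound 2 to compound 3 (0.18 log units; within the scatter) shows that a small change at the oxygen-bearing chain leaves the number within the scatter.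

On this basis compound 4 is expected to give a number in this assay close to that of compound 3, with the estimated step of a 1.1-fold higher number from compound 3 to compound 4 (0.06 log units; within the scatter) not clearly beyond the scatter in either direction. The estimate for compound 4 is 1000 nM, with a range from 300 nM to 3500 nM.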

Compound 4, inhibition constant: 2090 nM
The estimate for compound 4 lay 2.1-fold (0.32 log units) below the measured number; low and high end bracket the measured number.
By their numbers in this assay, from the lowest: compound 1; then compounds 3, 2 and 4 (each within the scatter of the next, the first and the last beyond it).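

In this assay, this aromatic carbon responds even to a change that leaves the count of heavy atoms and hydrogen-bond acceptors the same: formyl in place of methoxy gives a 2.4-fold higher number from compound 3 to compound 4 (0.38 log units; beyond the scatter). Formyl and ethoxy cannot be told apart, as a 1.6-fold higher number from compound 2 to compound 4 (0.20 log units; within the scatter) shows, while formyl in place of ethyl gives a 7.4-fold higher number from compound 1 to compound 4 (0.87 log units; beyond the scatter), the widest step among these four compounds, which leaves ethyl with the lowest number. No measurement shown here explains these differences.

The four groups compared are too few to show what the number at this carbon depends on. Going by these compounds, it remains open whether a longer chain such as propyl would keep the lower number seen with ethyl, and how an amine or a carboxylic acid at the same carbon would read.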